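Ester for Ether on a Choline Kinase Binder

The compounds below may be only part of what the source reports. "The series", "measured", "known", "first", "only" and "open" are said of these compounds alone.

Compound 1 `COc1ccc(-c2ccc(CN3CCCN(C)CC3)cc2)cc1` and compound 2 `CN1CCCN(Cc2ccc3ncccc3c2)CC1` were both tested in an assay on isolated protein for binding affinity to choline kinase alpha (Homo sapiens), read by surface plasmon resonance; on this read-out higher numbers stand for weaker binding and lower numbers for tighter binding. In this assay compound 1 gives 3800 nM. Compound 2 gives 4000 nM in this assay, a number within the scatter of that of compound 1, so neither stands apart. Compound 3 `COC(=O)c1ccc(-c2ccc(CN3CCCN(C)CC3)cc2)cc1` carries methoxycarbonyl in place of methoxy on an aromatic carbon, methoxycarbonyl in place of methoxy on an aromatic carbon. Among the measured compounds shown here, no measured pair shows this change, and the expected step of a 1.1-fold higher number from compound 1 to compound 3 (0.02 log units; within the scatter) is one that stays within the scatter. Compound 3 is thus estimated at 4000 nM, with a range from 1500 nM to 11000 nM.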

Compound 3, dissociation constant: 2400 nM
Compound 3: the middle estimate sits 1.7-fold (0.22 log units) above what was measured, and the stated range covers the measured number.
By their numbers in this assay, from the lowest: compounds 3, 1 and 2 (each within the scatter of the next).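

In this assay, methoxycarbonyl in place of methoxy on an aromatic carbon, para to a large group, gives a 1.6-fold lower number from compound 1 to compound 3 (0.20 log units; within the scatter) and so stays inside the scatter. The position therefore takes the larger group, with its added carbonyl, and compound 3 reads alike with compound 1. Nothing at hand accounts for this result.

Still open, going by these compounds, is whether a carboxylic acid or a primary amide at this position would read differently. On these data alone, it is equally open whether an amine there would stay within the scatter of compound 1.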